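Swapping a hydroxypentyl tail for a substituted phenyl ring

The source may report more compounds than this note shows. Statements on the series, on what has been measured and on what is new or still open speak of the compounds shown alone.

Measured compounds:
compound 1, `COc1cc(NC(C)CCCNC(=O)NNC(=O)NCCCCCO)c2ncccc2c1`, 54%
compound 2, `COc1ccc(C(=NNC(=O)NNC(=O)NCCCC(C)Nc2cc(OC)cc3cccnc23)c2ccc(OC)cc2)cc1`, 82%

Of the compounds shown here, two have been measured in a physicochemical assay for inhibition, read by spectrophotometry, tested at 100 uM; on this read-out lower numbers stand for less inhibition and higher numbers for more inhibition at the one concentration tested (going by the name of the read-out). Compound 1 gives 54%, and compound 2 gives 82%. Compound 1 therefore stands at the lower of the two numbers, and the gap to compound 2 lies beyond the scatter of repeated measurements.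

Compound 3, `COc1cc(NC(C)CCCNC(=O)NNC(=O)Nc2ccc(Cl)c(C(F)(F)F)c2)c2ncccc2c1`, has not yet been measured. It differs from compound 1 in one place: 4-chloro-3-(trifluoromethyl)phenyl in place of 5-hydroxypentyl on an amide-type nitrogen. A flexible chain ending in a hydroxyl leaves, and a halogen-bearing aromatic ring enters on an amide-type nitrogen whose other neighbour is a carbonyl carbon.

Among the compounds with values here, no pair of measured compounds differing in a single place exists here, so the size of this step in this assay cannot be read from a known step. The expectation is a modest rise, since the compound with more aromatic rings, compound 2, gives 82%, though a change within the scatter is also plausible. Compound 3 is expected to give 65%, with a range from 45% to 85%, which means an expected step of a number 11 percentage points higher from compound 1 to compound 3 (beyond the scatter).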

Compound 3, a percentage reported as inhibition, at one concentration (the size of the read-out at that concentration, not a potency): 63%
The estimate for compound 3 lay 2 percentage points above the measured number; low and high end bracket the measured number.
By their numbers in this assay, from the lowest: compounds 1 and 3 (each within the scatter of the next); then compound 2.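

In this assay the exchange at this amide-type nitrogen reads a number 9 percentage points higher from compound 1 to compound 3 (within the scatter), so the difference between these two compounds cannot be told apart from the usual spread of repeat measurements. The exchange itself is not a small one: a flexible chain with no ring, ending in a hydroxyl, gives way to a larger aromatic ring carrying chlorine and trifluoromethyl, with no hydrogen-bond donor or acceptor. For this one pair, then, the terminal hydroxyl is not needed for a reading of this size, and this position accepts either an open chain or a halogen-bearing aromatic ring; nothing available explains this outcome.

This single pair cannot separate the contribution of the ring from that of its two substituents, so an unsubstituted phenyl ring would be the informative comparison. A pentyl chain ending in an amine or a carboxylic acid instead of a hydroxyl, or a longer chain, would show whether the chain's end or its length has any bearing on the reading.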